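This account rests on a few compounds, and the source may have more. Where it says the series, first, only, none or still open, it means among the compounds named here.

Measured so far:
- compound 1 `COc1cc(OC)c2c(=O)cc(-c3ccc(OCCBr)cc3)oc2c1`: "not active" (no number reported)
- compound 2 `COc1cc(OC)c2c(=O)cc(-c3ccc(OCCF)cc3)oc2c1`: "not active" (no number reported)
- compound 3 `COc1cc(OC)c2c(=O)cc(-c3ccc(OCC(O)CN4CCCC4)cc3)oc2c1`: 37%

For the measured compounds named here, in a functional assay (Homo sapiens) for antiproliferative activity, read by resazurin assay, with a stated time of 48 h, tested at 10 uM (a higher number here means a stronger effect of the compound at the concentration tested, a lower number a weaker effect), compound 3 gives the only number in the set; compound 1 and compound 2 come back without one. Compound 4 `COc1cc(OC)c2c(=O)cc(-c3ccc(Br)cc3)oc2c1` is not yet measured. Relative to compound 3 the change is bromo in place of 2-hydroxy-3-(pyrrolidin-1-yl)propoxy on an aromatic carbon. Going by the values given here, no step between measured compounds is available, so the size of this one is open. Compound 1 gave "not active" (no number reported) and compound 2 gave "not active" (no number reported), both carrying shorter chains at the same place, so a drop beyond the scatter is expected on going from compound 3 to compound 4. Compound 4 is expected to give about 15% (range 0% to 40%), a step of a number 22 percentage points lower from compound 3 to compound 4 (beyond the scatter) from compound 3.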

Compound 4, a percentage reported as inhibition, at one concentration (the size of the read-out at that concentration, not a potency): 10%
Estimate against measurement, compound 4: 5 percentage points above; measured number inside the range.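

In this assay, for the compounds shown here, bromo in place of 2-hydroxy-3-(pyrrolidin-1-yl)propoxy on the aromatic carbon gives a number 27 percentage points lower from compound 3 to compound 4 (beyond the scatter) and is the first step of known size at this position. Compound 4 reads 10% even with only a bromo there, whereas compound 1 and compound 2 carry no number. Nothing measured here accounts for the step.

Which part of the large group matters remains open. A piperidine or dimethylamine in place of the pyrrolidine, or a propoxy chain without the hydroxyl, would separate the amine from the chain.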